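The source may hold more compounds than are shown below. What is called first, only, known or untested is meant among the compounds shown, and "the series" means these compounds.

Measured so far in a functional assay on UACC-257 cells (Homo sapiens) for inhibition, read by sulforhodamine B assay, with a stated time of 48 h; on this read-out higher numbers stand for weaker inhibition of growth and lower numbers for stronger inhibition of growth:
- compound 1 `CC(C)c1ccc(Nc2ccc3c(OCCCN4CCN(C)CC4)cccc3n2)cc1` gives 5650 nM
- compound 2 `CN1CCN(CCCOc2cccc3nc(Nc4cccc(Cl)c4)ccc23)CC1` gives 1810 nM
- compound 3 `CN1CCN(CCCOc2cccc3nc(Nc4cc(Cl)cc(Cl)c4)ccc23)CC1` gives 1970 nM

Compound 1 carries the highest number of the three, and both steps away from it lie beyond the scatter, so on this read-out compound 1 is the weakest inhibitor of growth of the measured set. Compound 2 and compound 3 sit within the scatter of each other: a 1.1-fold higher number from compound 2 to compound 3 (0.04 log units; within the scatter).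

Compound 4 `CN1CCN(CCCOc2cccc3nc(Nc4ccc(Cl)c(F)c4)ccc23)CC1` is not yet measured. Against compound 1 the difference is 4-chloro-3-fluorophenyl in place of 4-isopropylphenyl on a nitrogen on an aromatic ring. For the measured compounds named here, two measured steps bear on this change, since each replaces the same group on the same nitrogen with a chloro-bearing phenyl: a 3.1-fold lower number from compound 1 to compound 2 (0.49 log units; beyond the scatter) and a 2.9-fold lower number from compound 1 to compound 3 (0.46 log units; beyond the scatter). Both steps were modest, both moved to lower numbers, and the second chloro in compound 3 added nothing beyond the scatter. The entering group in compound 4 again carries a chloro, joined by a fluoro, so a step of the same kind and size is expected, toward a lower number, placing compound 4 near compound 2 and compound 3 rather than near compound 1. The expected value for compound 4 is 2100 nM, with a range of 1100 nM to 4200 nM. This corresponds to an expected step of a 2.7-fold lower number from compound 1 to compound 4 (0.43 log units; beyond the scatter).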

Compound 4, concentration for 50% growth inhibition: 2040 nM
Compound 4: middle estimate off by 1.0-fold (0.01 log units), on the high side, and the stated range covers the measured number.
By their numbers in this assay, from the lowest: compounds 2, 3 and 4 (each within the scatter of the next); then compound 1.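

In this assay, a third chloro-bearing group on a nitrogen on an aromatic ring again moves the number away from compound 1, a 2.8-fold lower number from compound 1 to compound 4 (0.44 log units; beyond the scatter), and this shows that the step also holds when the entering group carries a fluoro as well as a chloro. Against the other two chloro-bearing groups, 4-chloro-3-fluorophenyl gives a 1.0-fold higher number from compound 3 to compound 4 (0.02 log units; within the scatter) and a 1.1-fold higher number from compound 2 to compound 4 (0.05 log units; within the scatter), so 3-chlorophenyl, 3,5-dichlorophenyl and 4-chloro-3-fluorophenyl cannot be told apart at this place, and the three different arrangements of halogens on the phenyl ring leave the number unchanged within the scatter. Nothing measured here offers an explanation for this shared level or for the gap to compound 1.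

Compound 1 is the only one of the four without a chloro, so the compounds shown cannot separate a gain from adding chloro from a loss caused by the isopropyl group, a question that unsubstituted phenyl or 4-methoxyphenyl at the same nitrogen would address. As far as these compounds go, it also remains open whether a group such as 3-trifluoromethylphenyl or 3-cyanophenyl would leave this level or stay on it.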